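Fluorine on the aniline ring of a thiophene acid

The source may report more compounds than this note shows. Statements on the series, on what has been measured and on what is new or still open speak of the compounds shown alone.

Of the compounds shown here, two of this set have been measured in a functional assay, with a stated time of 150 min, tested at 5 ug/mL; a lower number here means a weaker effect, a higher number a stronger effect of the compound at the concentration tested. Compound 1 `COC(=O)c1c(Nc2ccccc2)sc(C(=O)c2ccc(OC)cc2)c1C` gives 13.3%, and compound 2 `COc1ccc(C(=O)c2sc(Nc3ccccc3)c(C(=O)O)c2C)cc1` gives 19.6%. Among the compounds with values here, the single measured step, a number 6.3 percentage points higher from compound 1 to compound 2 (within the scatter), came with hydrogen in place of methyl on an oxygen next to a carbonyl group; compound 2 therefore stands alongside compound 1, the two numbers not separable from each other within the scatter of this assay.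

Compound 3 `COc1ccc(C(=O)c2sc(Nc3ccc(F)cc3)c(C(=O)O)c2C)cc1` has not yet been measured. It differs from compound 2 by fluoro in place of hydrogen on an aromatic carbon. Within the data shown here, no measured step involves a change at this part of the structure, so nothing among the measured compounds speaks to its size or direction; the one step available concerns a different place and was itself within the scatter. The step of a number 0.4 percentage points higher from compound 2 to compound 3 (within the scatter) is therefore expected to stay within the scatter. On that basis compound 3 is estimated to give about 20%, in a range from 8% to 34%.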

Compound 3, a percentage reported as activity, at one concentration (the size of the read-out at that concentration, not a potency): 0.1%
Compound 3: the middle estimate sits 19.9 percentage points above what was measured; the whole stated range lies above it.
By their numbers in this assay, from the lowest: compound 3; then compounds 1 and 2 (each within the scatter of the next).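

In this assay the aromatic carbon para to a large group turns out to matter: the change from phenyl to 4-fluorophenyl comes with a number 19.5 percentage points lower from compound 2 to compound 3 (beyond the scatter) and so, unlike the earlier change at the acid, it separates two compounds. A single fluoro at this place leaves compound 3 at 0.1% in this read-out, so the anilino part of the structure is not a neutral place for substitution here. Nothing available explains this loss.

Whether the drop belongs to fluoro alone remains open, since no chloro, methyl or amine at the same carbon appears among these compounds. Also open, going by these compounds, is whether the same fluoro would lower the number for the methyl ester, compound 1, as it does for the acid.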